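One Fluorine Atom Added to Compound 2

A few compounds are considered here, and "the series" means these few. Any claim that something is new, unique, unknown or untested is made for them only; others in the source may bear on it.

Of the compounds shown here, three have been measured so far, and all share the same core. Compound 1 `O=C(O)Cc1sc(COc2ccc(Cl)cc2)nc1-c1ccc(Cl)cc1` carries two chlorinated aromatic rings. Compound 2 `O=C(O)Cc1sc(C(c2ccc(F)cc2)c2ccc(F)cc2)nc1-c1ccccc1` and compound 3 `O=C(O)Cc1sc(C(c2ccccc2)c2ccc(Cl)cc2)nc1-c1ccc(Cl)cc1` instead carry two aromatic rings on a single carbon attached to the core, with fluorine or chlorine spread differently over the rings.

In an in vitro assay on HEK385-7 cells for displacement of a labelled ligand from prostaglandin D2 receptor 2 (Homo sapiens) (on this read-out higher numbers stand for weaker inhibition and lower numbers for stronger inhibition), compound 1 gives 32 nM, compound 2 gives 16 nM and compound 3 gives 45 nM. Compound 2 has the lowest of these three numbers. Its gap to compound 1 lies within the usual scatter of repeated measurements, so those two cannot be ordered with confidence, while its gap to compound 3 lies beyond the scatter.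

Compound 4 `O=C(O)Cc1sc(C(c2ccc(F)cc2)c2ccc(F)cc2)nc1-c1cccc(F)c1` differs from compound 2 in one place: fluoro in place of hydrogen on an aromatic carbon. Everything else in the structure stays the same.

For the measured compounds named here, no pair among the measured compounds differs in exactly this way, so there is no measured step to lean on. A single fluorine on an aromatic carbon is among the smallest changes available, and in this assay it is expected to move the number little, in no sure direction. The expected step, a 1.1-fold higher number from compound 2 to compound 4 (0.05 log units; within the scatter), stays inside the scatter. Compound 4 is therefore estimated at 18 nM, with a likely range from 7 nM to 45 nM.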

Compound 4, half-maximal inhibitory concentration: 1.4 nM
Estimate against measurement, compound 4: 13-fold (1.11 log units) above, and the stated range ends above it.
By their numbers in this assay, from the lowest: compound 4; then compounds 2, 1 and 3 (each within the scatter of the next, the first and the last beyond it).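

In this assay, replacing phenyl with 3-fluorophenyl gives an 11-fold lower number from compound 2 to compound 4 (1.06 log units; beyond the scatter), a large change that lies well beyond the scatter. The added group is a single heavy atom with no ring, no charge and no hydrogen-bond donors or acceptors, so even a very small edit at this place on the aromatic ring can strongly shift the number. For the compounds shown here, the earlier compounds could not show this, since none of them formed a pair differing in one place, and this is the first step that ties a change in the number to one specific edit. Nothing shown here explains why this one atom shifts the number so much.

The compounds shown leave open whether a methyl, a methoxy or an amine at this same place would give a similar step, or whether fluoro is special here. Also open, going by these compounds, is whether adding fluoro would do the same on the other compounds, such as compound 1 and compound 3, whose matching ring already carries chlorine.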